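A few compounds are considered here, and "the series" means these few. Any claim that something is new, unique, unknown or untested is made for them only; others in the source may bear on it.

Compound 1, with the structure `C=Cc1ccc(Sc2ccccc2CN(C)C)c(N)c1`, is examined in an in vitro assay on cells (kidney) for binding affinity to sodium-dependent dopamine transporter (Homo sapiens) (a higher number here means a weaker inhibitor, a lower number a stronger inhibitor), where compound 1 gives 962 nM. Compound 2, with the structure `CCc1ccc(Sc2ccccc2CN(C)C)c(N)c1`, differs from it by an ethyl group in place of the vinyl group on an aromatic carbon. In this assay compound 2 reaches only > 2000 nM, which is a limit of the assay and not a measured number. That change gives an at least 2.0-fold higher number from compound 1 to compound 2 (0.31 log units; beyond the scatter), a loss whose size rests on (the limit of > 2000 nM in this assay, at which 1 of the 2 values shown sits). Compound 2 thus stands at the weak end of the two numbers shown, sitting at the limit itself. Compound 3, with the structure `CN(C)Cc1ccccc1Sc1ccc(CCO)cc1N`, carries hydroxy in place of hydrogen on a saturated chain carbon, two bonds along the chain from an aromatic carbon. Among the compounds with values here, no measured step here involves a hydroxy group; the single step recorded, from vinyl to ethyl, already left compound 2 at a limit, so the data give no direct guide to the size of the next step. The step that the limit leaves unreadable from compound 2 to compound 3 is what is expected, essentially no movement beyond the scatter. Compound 3 is estimated at 3000 nM, within the range from 800 nM to 12000 nM.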

Compound 3, inhibition constant: > 1000 nM
Compound 3: a limit, no number (the forecaster's own chance of this, stated with the estimate: 60%); the middle value lies beyond the limit too.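

The hydroxy group on the saturated chain carbon, two bonds along the chain from an aromatic carbon, is new with compound 3, and in this assay compound 3 also ends at a limit of the assay and not a number: the limit of > 1000 nM in this assay, at which 1 of the 3 values shown sits.

Compound 2 and compound 3 both stand at limits, so the step between them cannot be read, and it shows neither a gain nor a loss from the hydroxy group. Putting 2-hydroxyethyl in place of vinyl gives an at least 1.0-fold higher number from compound 1 to compound 3 (0.01 log units; that floor lies within the scatter), so this floor does not separate the two compounds, and the true gap could be negligible or large.

Still open, from the compounds shown here alone, is whether any group at the end of this chain can give a measured number in this assay rather than a limit, as an amine, a carboxylic acid or a longer chain ending in hydroxy might. Also open, going by these compounds, is whether the vinyl group of compound 1 is special, which a group such as an ethynyl or a propenyl on the same aromatic carbon would help to show.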